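The source may hold more compounds than are shown below. What is called first, only, known or untested is meant among the compounds shown, and "the series" means these compounds.

Measured so far:
compound 1 `COc1cc(Cl)cc(-c2nn(-c3cccc(NC(=O)Nc4ccc(Cl)c(C(F)(F)F)c4)c3)cc2-c2ccncc2)c1` gives -10.4% in a functional assay on NCI-H522 cells (Homo sapiens) for inhibition, read by sulforhodamine B assay, with a stated time of 48 h, tested at 10 uM; a higher number here means a weaker effect of the compound at the concentration tested, a lower number a stronger effect
compound 2 `COc1cc(Cl)cc(-c2nn(-c3cccc(NC(=O)Nc4ccc(Cl)c(Cl)c4)c3)cc2-c2ccncc2)c1` gives -19% in this assay

Compound 1 stands with compound 2 inside the usual scatter: the step of a number 8.6 percentage points lower from compound 1 to compound 2 (within the scatter) does not separate them. Compound 3 `COc1cc(Cl)cc(-c2nn(-c3cccc(NC(=O)c4cccc(C(F)(F)F)c4)c3)cc2-c2ccncc2)c1` differs from compound 1 in one place: 3-(trifluoromethyl)phenyl in place of (4-chloro-3-(trifluoromethyl)phenyl)amino on a carbonyl carbon. Going by the values given here, no measured step bears on this change; the only step known, chloro in place of trifluoromethyl on an aromatic carbon, concerns a different part of the molecule. The step of a number 5.4 percentage points higher from compound 1 to compound 3 (within the scatter) is therefore expected to be small, with a wide range around it. Compound 3 is estimated at -5%, between -40% and 30%.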

Compound 3, a percentage reported as activity, at one concentration (the size of the read-out at that concentration, not a potency): 32.2%
Estimate against measurement, compound 3: 37.2 percentage points below, outside the stated range (above it).
By their numbers in this assay, from the lowest: compounds 2 and 1 (each within the scatter of the next); then compound 3.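

At this carbonyl carbon, 3-(trifluoromethyl)phenyl in place of (4-chloro-3-(trifluoromethyl)phenyl)amino weakens the effect in this assay, with a number 42.6 percentage points higher from compound 1 to compound 3 (beyond the scatter). The same replacement of (3,4-dichlorophenyl)amino gives a number 51.2 percentage points higher from compound 2 to compound 3 (beyond the scatter), so both groups that leave carry a clear weakening that the chloro and trifluoromethyl exchange did not show. Nothing available accounts for this change in the read-out. The change removes the amino nitrogen and the ring chlorine together, and the compounds shown do not separate the two. From the compounds shown here alone, how (3-(trifluoromethyl)phenyl)amino or a simple amine on this carbonyl carbon would read stays open.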